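Cyanosulfanyl to selenium analogue: growth inhibition in two cores

The compounds below may be only part of what the source reports. "The series", "measured", "known", "first", "only" and "open" are said of these compounds alone.

The series pairs a cyanosulfanyl methyl group with its selenium counterpart on two unrelated cores. Compound 1 `N#CSCN1C(=O)c2ccccc2C1=O` carries the sulfur group on the saturated chain carbon bound to an amide-type nitrogen in a ring. In a functional assay on MCF7 cells (Homo sapiens) for cytotoxicity, read by MTT assay, with a stated time of 72 h (a higher number here means a weaker inhibitor of growth, a lower number a stronger inhibitor of growth), compound 1 reaches only a limit, > 100000 nM, and is not given as a number; it rests at the limit of > 100000 nM in this assay, at which 1 of the 3 values shown sits. Compound 2 `N#C[Se]CN1C(=O)c2ccccc2C1=O` is the selenium analogue, and in this assay compound 2 gives 56100 nM. The step is an at least 1.7-fold lower number from compound 1 to compound 2 (0.25 log units; that floor lies within the scatter), made by the change (a group of 3 heavy atoms (1 carbon, 1 nitrogen, 1 selenium; no ring) in place of a group of 3 heavy atoms (1 carbon, 1 nitrogen, 1 sulfur; no ring), on a saturated chain carbon bound to an amide-type nitrogen in a ring).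

Compound 3 `N#CSCc1ccc(-n2cccc2)cc1` places the cyanosulfanyl group on a different core, and in this assay compound 3 gives 36900 nM. Against compound 2 the gap is within the scatter, so no order between compound 2 and compound 3 is claimed. The difference between the core of compound 3 and the core of compound 1 is not broken down here.

Compound 4 `N#C[Se]Cc1ccc(-n2cccc2)cc1` is the selenium analogue of compound 3; the change is a group of 3 heavy atoms (1 carbon, 1 nitrogen, 1 selenium; no ring) in place of a group of 3 heavy atoms (1 carbon, 1 nitrogen, 1 sulfur; no ring), on a saturated chain carbon bound to an aromatic carbon. The place differs from that in compound 1 and compound 2, where the saturated chain carbon is bound to an amide-type nitrogen in a ring rather than to an aromatic carbon, so this is the same kind of change, not the same change. Going by the values given here, a step of about a 1.8-fold lower number from compound 3 to compound 4 (0.27 log units; within the scatter) is expected, resting on the single earlier step, whose floor lies within the scatter. In this assay compound 4 is estimated at 20000 nM, with a range from 8000 nM to 50000 nM.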

Compound 4, concentration for total growth inhibition: > 100000 nM
Compound 4 was reported as a limit (the forecaster's own chance of this, stated with the estimate: 5%); at least 5.0-fold (0.69 log units) between middle value and limit.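

Carrying the exchange of the cyanosulfanyl group for its selenium counterpart from the core of compound 1 to the core of compound 3 does not preserve the outcome in this assay, as the two steps differ by more than the scatter: the same change on two cores in this assay, an at least 1.7-fold lower number (0.25 log units; that floor lies within the scatter) from compound 1 to compound 2 and an at least 2.7-fold higher number (0.43 log units; beyond the scatter) from compound 3 to compound 4, at least 4.8-fold (0.68 log units) apart, beyond the scatter of two such steps

The new step, an at least 2.7-fold higher number from compound 3 to compound 4 (0.43 log units; beyond the scatter), is a clear loss of growth inhibition on this core, but it gives only a floor, and the step on the other core is likewise a floor, since each rests on a limit and not a number: the limit of > 100000 nM in this assay, at which 2 of the 4 values shown sit.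

This shows that the effect of the exchange depends on the core in this pair of pairs, but it does not give the true size of either step, does not firmly set the direction on the core of compound 1, and offers no explanation for the difference.

With only two cores shown, it remains open whether the selenium exchange lowers or raises the number on a third core, for example one carrying an amine or a carboxylic acid. Going by these compounds, it also remains open whether a longer chain in place of the saturated chain carbon would keep the difference between the two cores.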